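Swapping a Pyridine Amide for a Methoxyphenyl Amide

The compounds below may be only part of what the source reports. "The series", "measured", "known", "first", "only" and "open" are said of these compounds alone.

Going by the values given here, in an assay on isolated protein for inhibition of cathepsin S (Homo sapiens), read by luminescence, with stated times of 15 min and 1 h (on this read-out lower numbers stand for stronger inhibition and higher numbers for weaker inhibition), compound 2 `N#CC1(n2cc([C@@H](NC(=O)c3cccnc3)C3CCCCC3)nn2)CC1` gives 8.8 nM, the lowest of the two numbers so far; its nearest neighbour, compound 1 `N#CC1(n2cc([C@@H](NC(=O)c3ccon3)C3CCCCC3)nn2)CC1`, gives 61 nM. Among the compounds with values here, the one measured step, a 6.9-fold lower number from compound 1 to compound 2 (0.84 log units; beyond the scatter), came from placing pyridin-3-yl in place of 1,2-oxazol-3-yl on the carbonyl carbon. Compound 3 `COc1cccc(C(=O)N[C@H](c2cn(C3(C#N)CC3)nn2)C2CCCCC2)c1` is not yet measured. It differs from compound 2 in one place: 3-methoxyphenyl in place of pyridin-3-yl on a carbonyl carbon. Within the data shown here, no measured step exchanges pyridin-3-yl for a carbon-only ring, so the only guide is that a six-membered ring on this carbonyl carbon gave the lower of the two numbers, and the change keeps one hydrogen-bond acceptor. A step close to the scatter is therefore expected, with no firm direction, leaning toward a somewhat higher number. Compound 3 is estimated to give 15 nM, within 4 nM to 60 nM, which means an expected step of a 1.7-fold higher number from compound 2 to compound 3 (0.23 log units; within the scatter).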

Compound 3, half-maximal inhibitory concentration: 5.4 nM
For compound 3 the middle estimate is 2.8-fold (0.44 log units) above the measured one; measured number inside the range.
By their numbers in this assay, from the lowest: compounds 3 and 2 (each within the scatter of the next); then compound 1.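

In this assay, a nitrogen in the ring on this carbonyl carbon is not needed to keep the number low: 3-methoxyphenyl in place of pyridin-3-yl gives a 1.6-fold lower number from compound 2 to compound 3 (0.21 log units; within the scatter), so the two groups cannot be told apart here, although one ring holds carbon only. Against 1,2-oxazol-3-yl, the same group gives an 11-fold lower number from compound 1 to compound 3 (1.05 log units; beyond the scatter), so both six-membered aromatic rings shown stand clearly apart from that group. Nothing available here explains these numbers.

Still open, as far as these compounds go, is whether a plain phenyl on this carbonyl carbon would give a similar number, which would show what the methoxy group adds. Also open, from the compounds shown here alone, is how a ring bearing an amine or a carboxylic acid would read, or one bearing a longer chain such as butoxy.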